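A Single Chloro Removed, With the Cell Effect Still Unknown

The compounds below may be only part of what the source reports. "The series", "measured", "known", "first", "only" and "open" are said of these compounds alone.

Compound 1 `COc1cc(Cl)cc(-c2nn(-c3cccc(NC(=O)Nc4ccc(Cl)c(C(F)(F)F)c4)c3)cc2-c2ccncc2)c1`: -89%
Compound 2 `COc1cc(Cl)cc(-c2nn(-c3cccc(NC(=O)Nc4cc(C(F)(F)F)cc(C(F)(F)F)c4)c3)cc2-c2ccncc2)c1`: -80%

Of the compounds shown here, two have been measured in a functional assay on OVCAR-5 cells (Homo sapiens) for inhibition, read by sulforhodamine B assay, with a stated time of 48 h, tested at 100 uM; a higher number here means a weaker effect of the compound at the concentration tested, a lower number a stronger effect. Compound 1 gives -89% in this assay, and compound 2 gives -80%. Of these two numbers, compound 1 holds the lower one, but its distance from compound 2 lies within the usual scatter of repeated measurements, so the two cannot be told apart on this evidence. A third compound, compound 3 `COc1cc(Cl)cc(-c2nn(-c3cccc(NC(=O)Nc4cccc(C(F)(F)F)c4)c3)cc2-c2ccncc2)c1`, has not yet been measured. It differs from compound 1 in one place: hydrogen in place of chloro on an aromatic carbon. Among the compounds with values here, no pair of measured compounds differing in a single position exists in this set, so no measured step is at hand to set a size for such a change. The step of a number 14 percentage points higher from compound 1 to compound 3 (beyond the scatter) is expected to be small and toward a weaker effect, possibly not beyond the scatter. Compound 3 is therefore estimated at -75%, within a range from -95% to -40%.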

Compound 3, a percentage reported as activity, at one concentration (the size of the read-out at that concentration, not a potency): -13%
For compound 3 the middle estimate is 62 percentage points below the measured one, and the stated range ends below it.
By their numbers in this assay, from the lowest: compounds 1 and 2 (each within the scatter of the next); then compound 3.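

In this assay, the second substituent on the ring carrying the 3-(trifluoromethyl)phenyl group proves to be far from a minor detail: hydrogen in place of chloro gives a number 76 percentage points higher from compound 1 to compound 3 (beyond the scatter), a large loss of effect from the removal of one heavy atom. Hydrogen in place of trifluoromethyl points the same way, with a number 67 percentage points higher from compound 2 to compound 3 (beyond the scatter), so among these compounds the strong effect is seen only where that ring carries a further group beyond the one trifluoromethyl of compound 3. Nothing available here explains why this change matters so much.

From the compounds shown here alone, what remains open is how far this extends to other groups, such as bromo, methyl, a nitrile or an amine, in place of the chloro. The compounds shown also cannot tell whether a substituent at this position must be a halogen or whether any group there would restore the effect.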